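Series notes: 3-methylphenyl to 3-ethylphenyl

The compounds below may be only part of what the source reports. "The series", "measured", "known", "first", "only" and "open" are said of these compounds alone.

- compound 1 `O=C1NCCN1c1ccc(S(=O)(=O)Nc2ccc3[nH]ccc3c2)cc1`: 410 nM
- compound 2 `Cc1cccc(NS(=O)(=O)c2ccc(N3CCNC3=O)cc2)c1`: 200 nM

In a functional assay on CCRF-CEM cells (Homo sapiens) for antiproliferative activity, read by sulforhodamine B assay, with a stated time of 48 h (on this read-out higher numbers stand for weaker inhibition and lower numbers for stronger inhibition), compound 2 (200 nM) holds the lower of the two numbers, and the gap to compound 1 (410 nM) lies beyond the usual scatter. Compound 3 `CCc1cccc(NS(=O)(=O)c2ccc(N3CCNC3=O)cc2)c1` is not yet measured. It differs from compound 2 by methyl in place of hydrogen on a saturated chain carbon bound to an aromatic carbon, which turns 3-methylphenyl into 3-ethylphenyl (methyl in place of hydrogen on a saturated chain carbon bound to an aromatic carbon). Going by the values given here, no measured pair shows a change of this kind, so the expectation rests only on compound 2 (200 nM). No step beyond the scatter is expected in this assay, in either direction. The estimated step of a 1.2-fold higher number from compound 2 to compound 3 (0.06 log units; within the scatter) is small and within the scatter. The estimate for compound 3 is 230 nM (expected range 100 nM to 530 nM).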

Compound 3, half-maximal inhibitory concentration: 200 nM
Compound 3: middle estimate off by 1.2-fold (0.06 log units), on the high side; the measured number falls inside the stated range.
By their numbers in this assay, from the lowest: compounds 2 and 3 (each within the scatter of the next); then compound 1.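

Working from 3-methylphenyl to 3-ethylphenyl gives the first one-place step in the series, and in this assay the step reads no change at the digits printed from compound 2 to compound 3 (within the scatter) with no difference beyond the scatter. At this position, methyl in place of hydrogen on a saturated chain carbon bound to an aromatic carbon is therefore tolerated, a point that compound 1 and compound 2 alone, which differ in more than one place, could not show. No measurement at hand speaks to the reason for this flat step.

On these data alone, whether this tolerance continues beyond ethyl remains open, as a longer chain such as propyl or a branched group such as isopropyl could still shift the number. A primary amine or a carboxylic acid at this position would test the series with something other than a plain alkyl group.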